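Swapping the chlorophenyl amide for an isoxazole

This account rests on a few compounds, and the source may have more. Where it says the series, first, only, none or still open, it means among the compounds named here.

Compound 1 `O=C(Nc1ccc(Cl)c(-c2nnc3c(Cl)cccn23)c1)c1ccc(Cl)cc1`: 73600 nM
Compound 2 `CS(=O)(=O)c1ccc(C(=O)Nc2ccc(Cl)c(-c3nnc4c(Cl)cccn34)c2)c(Cl)c1`: a limit of the assay, > 100000 nM

Both compounds share the same core and were tested in a functional assay on A549 cells (Homo sapiens) for antiproliferative activity, read by MTT assay, with a stated time of 72 h; on this read-out lower numbers stand for stronger inhibition and higher numbers for weaker inhibition. Compound 1 gives 73600 nM in this assay, and this is the only actual number shown. Compound 2 reaches only the limit of the assay, > 100000 nM, which is the situation described in the limit of > 100000 nM in this assay, at which 1 of the 2 values shown sits. So compound 1 is a weak inhibitor, and nothing measured so far is stronger.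

Compound 3 `O=C(Nc1ccc(Cl)c(-c2nnc3c(Cl)cccn23)c1)c1ccon1` has not yet been measured. It differs from compound 1 in one place: 1,2-oxazol-3-yl in place of 4-chlorophenyl on a carbonyl carbon. Among the compounds with values here, since no step between two measured compounds is known here, there is no measured precedent for this change. Given how weak compound 1 is at 73600 nM, the step of a 1.2-fold higher number from compound 1 to compound 3 (0.09 log units; within the scatter) is expected to be small, within or near the scatter, possibly toward weaker inhibition. Compound 3 is therefore estimated at 90000 nM in this assay, within a range of 30000 nM to 300000 nM.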

Compound 3, half-maximal inhibitory concentration: 42700 nM
Compound 3: the middle estimate sits 2.1-fold (0.32 log units) above what was measured; low and high end bracket the measured number.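

Replacing 4-chlorophenyl with 1,2-oxazol-3-yl on this carbonyl carbon gives, in this assay, a 1.7-fold lower number from compound 1 to compound 3 (0.24 log units; within the scatter), so the two groups cannot be told apart on this read-out. This gives the first measured view of this position: the chlorine and the carbon-only six-membered ring can both leave, and a five-membered aromatic ring with two hetero atoms can enter, without a change beyond the usual scatter. Nothing shown bears on why the two groups read alike.

Going by these compounds, compound 1 and compound 3 are both weak, so it remains open whether any group on this carbonyl carbon can move the number clearly beyond the scatter, for instance a saturated ring such as piperidine or a phenyl ring carrying a carboxylic acid or an amine. On these data alone, it also remains open whether changes elsewhere on the shared core, such as an amine in place of one of its chlorine atoms, would matter more than this swap did.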